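From a limit to a tetrazole on the shared core

The source may report more compounds than this note shows. Statements on the series, on what has been measured and on what is new or still open speak of the compounds shown alone.

In a functional assay (blood) for inhibition, with Homo sapiens as the target (on this read-out lower numbers stand for stronger inhibition and higher numbers for weaker inhibition), compound 1 `COC(C)c1cc(-c2ccccc2)c2ccc(OCc3cccc(C4(O)CCOCC4)c3)cc2c1` reaches only a limit, > 1000 nM. Compound 2 `N#Cc1cc(-c2ccccc2)c2ccc(OCc3cccc(C4(O)CCOCC4)c3)cc2c1` gives 100 nM. Compound 3 `OC1(c2cccc(COc3ccc4c(-c5ccccc5)cc(-c5nn[nH]n5)cc4c3)c2)CCOCC1` carries 2H-tetrazol-5-yl in place of 1-methoxyethyl on an aromatic carbon. Within the data shown here, one measured step bears on this change, at the same place: an at least 10-fold lower number from compound 1 to compound 2 (1.00 log units; beyond the scatter), with cyano in place of 1-methoxyethyl. On that single step, a shift in the same direction is expected in this assay, though its size is uncertain. The expected step is an at least 2.5-fold lower number from compound 1 to compound 3 (0.39 log units; beyond the scatter). For compound 3 the estimated value is 400 nM, with an expected range of 80 nM to 2000 nM.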

Compound 3, half-maximal inhibitory concentration: > 3000 nM
Compound 3 was reported as a limit; the forecaster's own chance of this, stated with the estimate: 20%; middle value at least 7.5-fold (0.87 log units) from the limit.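

At this place, para to a fused ring, 2H-tetrazol-5-yl in place of cyano gives an at least 30-fold higher number from compound 2 to compound 3 (1.47 log units; beyond the scatter) in this assay, so the gain seen with cyano does not extend to this ring. Compound 3 reaches only a limit of the assay: the limit of > 3000 nM in this assay, at which 1 of the 3 values shown sits.

The step from compound 1 to compound 3 cannot be read because compound 1 is also only a limit: the limit of > 1000 nM in this assay, at which 1 of the 3 values shown sits.

As far as these compounds go, how a carboxylic acid or an amine at this place would read in this assay stays open, as does how far compound 3 lies beyond its limit.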